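The source may report more compounds than this note shows. Statements on the series, on what has been measured and on what is new or still open speak of the compounds shown alone.

In a functional assay on MCF7 cells (Homo sapiens) for cytotoxicity, read by resazurin assay, with a stated time of 72 h (on this read-out higher numbers stand for weaker inhibition and lower numbers for stronger inhibition), compound 2 `Cc1nc2cc(C(=O)N/N=C\c3ccco3)c([N+](=O)[O-])cc2[nH]1` gives 81000 nM, and that is the only number among the three results shown for this series. Compound 1 `CC(C)=NNC(=O)c1ccc2[nH]c(C)nc2c1` gives > 100000 nM in this assay, which is a limit of the measurement rather than a number. Compound 3 `Cc1nc2cc(C(=O)N/N=C\c3ccc(C)o3)c([N+](=O)[O-])cc2[nH]1` likewise gives > 100000 nM in this assay, again a limit. Within the data shown here, the one step that can be read, an at least 1.2-fold higher number from compound 2 to compound 3 (0.09 log units; that floor lies within the scatter), comes from a methyl in place of hydrogen on an aromatic carbon, and its floor sits within the scatter; it is bounded by the limit of > 100000 nM in this assay, at which 2 of the 3 values shown sit.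

Compound 4 `Cc1nc2cc(C(=O)N/N=C\c3c[nH]c4ccccc34)c([N+](=O)[O-])cc2[nH]1` differs from compound 2 by 1H-indol-3-yl in place of furan-2-yl on a carbon with a double bond to nitrogen. The measured step from compound 2 to compound 3 concerns a small change on the furan ring that leaves, not the ring exchange itself, so it offers only a weak guide; the expectation is that in this assay no step beyond the scatter is warranted, and the step from compound 2 to compound 4 is estimated as a 1.4-fold lower number from compound 2 to compound 4 (0.13 log units; within the scatter). Compound 4 is therefore expected to give about 60000 nM in this assay, within a range from 12000 nM to 200000 nM, with a fair chance that only a limit is recorded.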

Compound 4, half-maximal inhibitory concentration: > 100000 nM
Compound 4: a limit, no number (the forecaster's own chance of this, stated with the estimate: 40%); middle value at least 1.6-fold (0.22 log units) away from the limit.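

In this assay compound 4 gives > 100000 nM, which is a limit and not a number. 1H-indol-3-yl in place of furan-2-yl on a carbon with a double bond to nitrogen gives an at least 1.2-fold higher number from compound 2 to compound 4 (0.09 log units; that floor lies within the scatter), so this larger ring exchange, like the methyl on the furan ring, shows no step beyond the scatter. Neither change at this place gives a number lower than that of compound 2, and the step between compound 3 and compound 4 cannot be read: the limit of > 100000 nM in this assay, at which 3 of the 4 values shown sit.

The compounds shown leave open whether a phenyl ring carrying an amine or a carboxylic acid on this same carbon would give a readable number in this assay. They also leave open what an amine in place of the nitro group on the shared core would give.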